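Two Methyl Groups Change Places on a Phenyl Ring

The source may hold more compounds than are shown below. What is called first, only, known or untested is meant among the compounds shown, and "the series" means these compounds.

Compound 1, `CCc1nc(-c2ccc(OC)c(OC)c2)c(C(=O)N2CCN(c3cccc(Cl)c3)CC2)o1`: "not active" (no number reported)
Compound 2, `Cc1ccc(N2CCN(C(=O)c3oc(C)nc3-c3ccccc3)CC2)c(C)c1`: 101 nM
Compound 3, `CCc1nc(-c2ccccc2Cl)c(C(=O)N2CCN(c3cccc(Cl)c3)CC2)o1`: 98.9 nM

All three were tested in a functional assay on HL-60 cells (Homo sapiens) for inhibition, read by MTT assay, with a stated time of 72 h; on this read-out higher numbers stand for weaker inhibition and lower numbers for stronger inhibition. Compound 1 is recorded in this assay as "not active" (no number reported), with no number attached, so it offers no point of comparison. Of the two numbers that exist, compound 2 sits at one end, yet compound 3 lies so close that the gap between them falls within the usual scatter of this assay, and the two count as alike rather than as ranked.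

Compound 4, `Cc1cc(C)cc(N2CCN(C(=O)c3oc(C)nc3-c3ccccc3)CC2)c1`, has not yet been measured. It shares every atom with compound 2, joined differently: 3,5-dimethylphenyl in place of 2,4-dimethylphenyl on an amine nitrogen in a ring. The two methyl groups thus move on the same phenyl ring, which keeps its attachment to the amine nitrogen in the ring. Among the compounds with values here, no pair of measured compounds shows what such a move does, so the size and direction of the step cannot be read from anything already known. With compound 2 and compound 3 alike in this assay despite larger differences between them, a change this modest is expected to stay within the scatter, in no particular direction.

Compound 4 is therefore estimated at 110 nM, with a likely range from 40 nM to 300 nM, which means an expected step of a 1.1-fold higher number from compound 2 to compound 4 (0.04 log units; within the scatter).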

Compound 4, half-maximal inhibitory concentration: 34.5 nM
Compound 4: middle estimate off by 3.2-fold (0.50 log units), on the high side; the whole stated range lies above it.
By their numbers in this assay, from the lowest: compound 4; then compounds 3 and 2 (each within the scatter of the next).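

In this assay, changing 2,4-dimethylphenyl to 3,5-dimethylphenyl on the amine nitrogen gives a 2.9-fold lower number from compound 2 to compound 4 (0.47 log units; beyond the scatter), a step that clears the usual scatter of repeated measurements. Within the data shown here, the earlier compounds offered no step of any kind, so this is the first sign that activity here responds to the arrangement of groups on this phenyl ring, and not only to which groups are present. The leaving and entering groups match in heavy atoms and in every count listed for them, which makes this a clean comparison of placement alone, yet nothing measured here shows why the new arrangement gives the lower number.

Among these compounds, with only this one pair, it remains open whether one methyl group or both account for the step, a question that a phenyl ring with a single methyl group or with no substituent at all could address. From the compounds shown here alone, it is equally open whether the methyl groups of 3,5-dimethylphenyl can be replaced by larger groups, such as two trifluoromethyl groups, or whether the same move would give a similar step on a core that carries an ethyl group.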